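Hydrazone series on HeLa cells: shift of the trifluoromethyl group

The compounds below may be only part of what the source reports. "The series", "measured", "known", "first", "only" and "open" are said of these compounds alone.

Measured so far:
compound 1 `Cc1nc(N(C)C(=O)NC(=O)c2ccc(Cl)cc2Cl)sc1C(=O)N/N=C/c1ccc(C(F)(F)F)cc1` 20.3 ug/mL
compound 2 `Cc1nc(N(C)C(=O)NC(=O)c2c(F)cccc2F)sc1C(=O)N/N=C/c1ccccc1C(F)(F)F` 6.51 ug/mL

Compound 2 gives the lowest number of the two in a functional assay on HeLa cells (Homo sapiens) for inhibition, read by MTT assay, with a stated time of 72 h; a higher number here means a weaker inhibitor, a lower number a stronger inhibitor; its nearest neighbour is compound 1, whose value lies beyond the scatter above it. Compound 3 `Cc1nc(N(C)C(=O)NC(=O)c2c(F)cccc2F)sc1C(=O)N/N=C/c1ccc(C(F)(F)F)cc1` carries 4-(trifluoromethyl)phenyl in place of 2-(trifluoromethyl)phenyl on a carbon with a double bond to nitrogen. Within the data shown here, no step between measured compounds isolates this change; compound 1 also holds 4-(trifluoromethyl)phenyl but differs elsewhere as well. A modest weakening is expected, a 1.8-fold higher number from compound 2 to compound 3 (0.27 log units; within the scatter), short of the gap to compound 1. Compound 3 is estimated at 12 ug/mL, between 5 ug/mL and 30 ug/mL.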

Compound 3, half-maximal inhibitory concentration: 40.6 ug/mL
Compound 3: middle estimate off by 3.4-fold (0.53 log units), on the low side; the whole stated range lies below it.
By their numbers in this assay, from the lowest: compound 2; then compounds 1 and 3 (each within the scatter of the next).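

In this assay, 4-(trifluoromethyl)phenyl in place of 2-(trifluoromethyl)phenyl on a carbon with a double bond to nitrogen gives a 6.2-fold higher number from compound 2 to compound 3 (0.79 log units; beyond the scatter), so with the same atoms, the placing of the trifluoromethyl group alone separates these two compounds. With 4-(trifluoromethyl)phenyl held, 2,6-difluorophenyl in place of 2,4-dichlorophenyl on a carbonyl carbon gives a 2.0-fold higher number from compound 1 to compound 3 (0.30 log units; within the scatter). No measurement on hand accounts for the first step. Open, from the compounds shown here alone, is whether 2,4-dichlorophenyl paired with 2-(trifluoromethyl)phenyl shows the same step, and whether a methoxy or nitrile group can replace the trifluoromethyl group.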